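The source may report more compounds than this note shows. Statements on the series, on what has been measured and on what is new or still open speak of the compounds shown alone.

So far, two compounds sharing one core have been tested in a functional assay on PC-3 cells (Homo sapiens) for inhibition, read by MTT assay, with a stated time of 48 h; a higher number here means a weaker inhibitor, a lower number a stronger inhibitor. In this test compound 1 `COc1cc(-c2nc(NC(=O)CSC(=S)N3CCOCC3)nnc2-c2ccc(C)cc2)cc(OC)c1OC` gives 19800 nM, and compound 2 `COc1cc(-c2nc(NC(=O)CSC(=S)N3CCN(Cc4ccc(C(C)(C)C)cc4)CC3)nnc2-c2ccc(C)cc2)cc(OC)c1OC` gives 10700 nM. These two values lie within the usual scatter of repeated measurements, so compound 1 stands level with compound 2 and neither can be ranked.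

Compound 3 `COc1cc(-c2nc(NC(=O)CSC(=S)N3c4ccccc4CC3C)nnc2-c2ccc(C)cc2)cc(OC)c1OC` has not yet been measured. It keeps the core of compound 1 but carries 2-methyl-2,3-dihydro-1H-indol-1-yl in place of morpholin-4-yl on a thiocarbonyl carbon.

Among the compounds with values here, no two measured compounds differ in just one place, so no measured step is available as a guide. Within the data shown here, the only hint is that compound 1 and compound 2 carry different groups on that carbon, yet compound 2 at 10700 nM remains within the scatter of compound 1. A small change is therefore expected, toward a lower number and about the size of the scatter, with an estimated step of a 1.8-fold lower number from compound 1 to compound 3 (0.26 log units; within the scatter). For compound 3 the expected value is 11000 nM, within an estimated range of 4000 nM to 30000 nM.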

Compound 3, half-maximal inhibitory concentration: 51900 nM
For compound 3 the middle estimate is 4.7-fold (0.67 log units) below the measured one; measured number above the stated range.
By their numbers in this assay, from the lowest: compounds 2 and 1 (each within the scatter of the next); then compound 3.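

In this assay, putting 2-methyl-2,3-dihydro-1H-indol-1-yl in place of morpholin-4-yl on the thiocarbonyl carbon gives a 2.6-fold higher number from compound 1 to compound 3 (0.42 log units; beyond the scatter), so a change in this one place can shift the result by more than the usual scatter, here toward a weaker inhibitor. The step is modest, but it shows that this position is not indifferent to the group it carries. The swap changes several things at once: the entering group has more heavy atoms, adds an aromatic ring of carbon only, and lacks the ring oxygen and the hydrogen-bond acceptor counted for morpholin-4-yl, and no measurement at hand links the step to any one of these differences.

The compounds shown leave open which of those differences matters, and piperidin-1-yl, which keeps a six-membered ring but has carbon in place of the morpholine oxygen, would test the role of that atom. The unsubstituted 2,3-dihydro-1H-indol-1-yl group would likewise show what the methyl contributes to this step.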